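Propyl for Isopropyl on the Ring Nitrogen of Compound 2

The source may hold more compounds than are shown below. What is called first, only, known or untested is meant among the compounds shown, and "the series" means these compounds.

Among the compounds with values here, compound 2 `CCCN(CCC)c1c(C)nc(-c2c(C)cc(C)cc2OC)n(C(C)C)c1=O` holds the lower of the two numbers so far: in an assay on IMR-32 cells for binding affinity to corticotropin-releasing factor receptor 1 (Homo sapiens) (a higher number here means a weaker inhibitor, a lower number a stronger inhibitor), compound 2 gives 47 nM, while compound 1 `CCCN(CCC)c1c(C)nc(-c2ccc(OC)cc2OC)n(CC2CC2)c1=O` gives 260 nM, a gap beyond the scatter. Compound 3 `CCCN(CCC)c1c(C)nc(-c2c(C)cc(C)cc2OC)n(CCC)c1=O` differs from compound 2 in one place: propyl in place of isopropyl on an aromatic nitrogen. Within the data shown here, no measured pair shows a step of this kind, so the expected step from compound 2 to compound 3 is a 1.3-fold higher number from compound 2 to compound 3 (0.11 log units; within the scatter), within the scatter. Compound 3 is estimated at 60 nM, in the range 25 nM to 150 nM.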

Compound 3, inhibition constant in the corticotropin-releasing factor receptor 1 assay: 190 nM
Compound 3: the middle estimate sits 3.2-fold (0.50 log units) below what was measured, outside the stated range (above it).
By their numbers in the corticotropin-releasing factor receptor 1 assay, from the lowest: compound 2; then compounds 3 and 1 (each within the scatter of the next).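

This position responds to how the same atoms are joined: with propyl in place of isopropyl on the aromatic nitrogen, the corticotropin-releasing factor receptor 1 assay shows a 4.0-fold higher number from compound 2 to compound 3 (0.61 log units; beyond the scatter) for this change alone. Compound 1 and compound 2 differ in more than one place, so they could not show this. In a physicochemical assay for solubility, at pH 7.4 (a higher number here means a more soluble compound, a lower number a less soluble compound), compound 2 gives < 0.1 ug/mL, which is a limit of the assay and not a number. In the physicochemical assay compound 3 gives < 0.1 ug/mL, which is also a limit of the assay. In the physicochemical assay the step between compound 2 and compound 3 cannot be read, as both sit at the limit of the assay: the limit of < 0.1 ug/mL in the physicochemical assay, at which 2 of the 2 values shown sit.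

On these data alone, how an ethyl group or a longer chain on this nitrogen would read in the corticotropin-releasing factor receptor 1 assay stays open. Whether a chain carrying a hydroxyl group or an amine would come off that limit in the physicochemical assay is open too.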